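This account rests on a few compounds, and the source may have more. Where it says the series, first, only, none or still open, it means among the compounds named here.

Working notes on the series.

Compound 1 `CCCCCCCCc1cc(-c2cn([C@H]3C[C@H](O)[C@@H](CO)O3)c(=O)[nH]c2=O)on1` was tested in a functional assay on HCT-15 cells (Homo sapiens) for cytotoxicity, read by sulforhodamine B assay, tested at 10 uM (on this read-out lower numbers stand for less inhibition and higher numbers for more inhibition at the one concentration tested (going by the name of the read-out)), and gives 88.2%. On the numbers available it stands lowest of the three measured compounds: compound 3 `CCCc1cc(-c2cn([C@H]3C[C@H](OC(C)=O)[C@@H](COC(C)=O)O3)c(=O)[nH]c2=O)on1` gives 98.8% in this assay, a number higher beyond the scatter, and compound 2 `CC(=O)OC[C@H]1O[C@@H](n2cc(-c3cc(C)no3)c(=O)[nH]c2=O)C[C@@H]1OC(C)=O` gives 102% in this assay, further above still, also beyond the scatter. For the measured compounds named here, the one measured step that changes a group on the same aromatic carbon is a number 3.2 percentage points lower from compound 2 to compound 3 (within the scatter), so lengthening the chain at that position left the read-out essentially where it was.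

Compound 4 `CC(C)(C)c1ccc(-c2cc(-c3cn([C@H]4C[C@H](O)[C@@H](CO)O4)c(=O)[nH]c3=O)on2)cc1` differs from compound 1 in one place: 4-(tert-butyl)phenyl in place of octyl on an aromatic carbon. Going by the values given here, no measured pair exchanges an alkyl chain for an aromatic ring, so the step from compound 2 to compound 3 bears on it only loosely, as the sole sign that changes at this position move the read-out little. Given that the measured step was within the scatter and all three measured compounds sit high, the step of a number 1.8 percentage points higher from compound 1 to compound 4 (within the scatter) is expected to be small, most likely upward, without confidence that it exceeds the scatter. Compound 4 is therefore estimated at 90% in this assay, within a range from 65% to 105%.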

Compound 4, a percentage reported as inhibition, at one concentration (the size of the read-out at that concentration, not a potency): 79.8%
Compound 4: middle estimate off by 10.2 percentage points, on the high side; the measured number falls inside the stated range.
By their numbers in this assay, from the lowest: compounds 4 and 1 (each within the scatter of the next); then compounds 3 and 2 (each within the scatter of the next).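

The exchange of octyl for 4-(tert-butyl)phenyl, on the aromatic carbon next to the ring nitrogen, gives in this assay a number 8.4 percentage points lower from compound 1 to compound 4 (within the scatter). Unlike the earlier step at this position, which only changed one alkyl group for another on a core bearing acetyl esters, this step replaces an open chain with a six-membered aromatic ring of carbon only, on the core with free hydroxyl groups, and the read-out does not move beyond the scatter. Within this one pair, therefore, a chain with no ring and a larger ring-bearing group cannot be told apart at the single concentration tested, and nothing available gives a reason for this outcome.

Still open, going by these compounds, is whether this position stays as undemanding when the group carries a charge-capable or hydrogen-bonding function, such as an amine or a carboxylic acid on the phenyl ring, in place of tert-butyl. Also open, on these data alone, is whether compound 1 and compound 4 would differ in potency, since a read-out at one concentration cannot show that.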